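A few compounds are considered here, and "the series" means these few. Any claim that something is new, unique, unknown or untested is made for them only; others in the source may bear on it.

Compound 1 `COc1ccc(-c2cc(=O)c3c(OC)cc(OC)cc3n2Cc2ccccc2)cc1` is one of two compounds with a result in a functional assay on SUP-B15 cells (Homo sapiens) for antiproliferative activity, with a stated time of 72 h; a lower number here means that less compound is needed, a higher number that more compound is needed for the effect. In this assay compound 1 gives > 34400 nM, which is a limit of the assay rather than a number (the limit of > 34400 nM in this assay, at which 1 of the 2 values shown sits). Compound 2 `COC(=O)c1cc(=O)c2cc(N)ccc2[nH]1` likewise gives > 67200 nM in this assay, again only a limit. Among the compounds with values here, compound 1 therefore stands on a limit alone, and no measured step joins it to another compound. Compound 3 `COc1ccc(-c2cc(=O)c3c(OC)cc(OC)cc3n2S(=O)(=O)c2ccc(C#N)cc2)cc1` differs from compound 1 by (4-cyanophenyl)sulfonyl in place of benzyl on an aromatic nitrogen. With nothing measured to build on, the expected change a step that the limit leaves unreadable from compound 1 to compound 3 is none beyond the scatter. Compound 3 is estimated at 40000 nM, between 8000 nM and 200000 nM.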

Compound 3, half-maximal effective concentration: 7900 nM
Compound 3: middle estimate off by 5.1-fold (0.70 log units), on the high side; measured number outside the range, below it.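

Putting (4-cyanophenyl)sulfonyl in place of benzyl on the aromatic nitrogen gives an at least 4.3-fold lower number from compound 1 to compound 3 (0.63 log units; beyond the scatter) in this assay. The group on this nitrogen of the shared core can therefore change the result, and compound 3 is the first compound shown with a true number rather than a limit. The full size of the step stays unknown because compound 1 stands on a limit: the limit of > 34400 nM in this assay, at which 1 of the 3 values shown sits.

As far as these compounds go, the sulfonyl and the nitrile entered together, so their separate shares remain open. From the compounds shown here alone, it is also open how an amine or a carboxylic acid in place of the nitrile would read.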